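Dropping the bromo substituent from a weakly cytotoxic isatin

The compounds below may be only part of what the source reports. "The series", "measured", "known", "first", "only" and "open" are said of these compounds alone.

Measured compounds:
- compound 1, `O=C1C(=O)N(CN(c2ccccc2)c2ccccc2)c2cccc(Br)c21`: 51100 nM
- compound 2, `Cc1ccc2nc(/N=C3\C(=O)N(CN4CCCCC4)c4cccc(Cl)c43)sc2c1`: 55800 nM

Two compounds were tested in a functional assay on MDA-MB-231 cells (Homo sapiens) for cytotoxicity, read by sulforhodamine B assay, with a stated time of 48 h; a lower number here means a stronger inhibitor of growth, a higher number a weaker inhibitor of growth. Compound 1 gives 51100 nM, and compound 2 gives 55800 nM. Compound 1 has the lowest number of the two, but its gap to compound 2 lies within the scatter of repeated measurements, so the two cannot be placed in order on these numbers. Going by the values given here, no pair among the measured compounds differs in a single place, so no step size has been measured.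

Compound 3, `O=C1C(=O)N(CN(c2ccccc2)c2ccccc2)c2ccccc21`, is the next compound to be examined in this assay. It differs from compound 1 by hydrogen in place of bromo on an aromatic carbon. Among the compounds with values here, the two known numbers are both weak and close to each other, and nothing measured here fixes how large the effect of this change will be. Because compound 1 gives 51100 nM, compound 3 is expected to stay in a weak range, with a modest step of a 1.5-fold higher number from compound 1 to compound 3 (0.17 log units; within the scatter) towards a higher number as the more likely direction. Compound 3 is therefore estimated at 75000 nM, with a range of 25000 nM to 200000 nM.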

Compound 3, concentration for 50% growth inhibition: 24800 nM
Estimate against measurement, compound 3: 3.0-fold (0.48 log units) above; measured number outside the range, below it.
By their numbers in this assay, from the lowest: compound 3; then compounds 1 and 2 (each within the scatter of the next).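

In this assay, going by these compounds alone, the replacement of bromo by hydrogen on this aromatic carbon gives a 2.1-fold lower number from compound 1 to compound 3 (0.31 log units; beyond the scatter) and is the first single change that can be read in this set, as compound 1 and compound 2 differ in more than one place. It shows that bromo is not required at this place for the growth inhibition seen with compound 1, and that the compound carrying hydrogen there is the stronger inhibitor of this pair, although compound 3 at 24800 nM remains a weak inhibitor of growth. The compounds shown offer no measured information that would account for this step.

As far as these compounds go, it remains open whether hydrogen would also improve on chloro in the core of compound 2, where other parts of the molecule differ as well. A single step also cannot show how other groups on this aromatic carbon, such as fluoro, methoxy or an amine, would stand against hydrogen and bromo in this assay, so no trend at this place can yet be drawn.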